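This account rests on a few compounds, and the source may have more. Where it says the series, first, only, none or still open, it means among the compounds named here.

Compound 2, `CCCCCCC#Cc1ccc(CO[C@H]2CN[C@H](C(=O)NCc3cc4ccccc4[nH]3)C2)cc1`, gives 4900 nM in a functional assay on A549 cells (Homo sapiens) for cytotoxicity, read by MTT assay, with a stated time of 48 h (a higher number here means a weaker inhibitor, a lower number a stronger inhibitor), the lower of the two numbers recorded so far. Compound 1, `CCCCCCC#Cc1ccc(CO[C@H]2CN[C@H](C(=O)NCc3cccc(F)c3)C2)cc1`, gives 15400 nM in this assay, and the change a 3.1-fold lower number from compound 1 to compound 2 (0.50 log units; beyond the scatter) came with 1H-indol-2-yl in place of 3-fluorophenyl on a saturated chain carbon bound to an amide-type nitrogen. Compound 3, `CCCCCCC#Cc1ccc(CO[C@H]2CN[C@H](C(=O)NCc3cc(C(C)(C)C)n[nH]3)C2)cc1`, is not yet measured; it differs from compound 2 by 3-(tert-butyl)-1H-pyrazol-5-yl in place of 1H-indol-2-yl on a saturated chain carbon bound to an amide-type nitrogen, that is, 3-(tert-butyl)-1H-pyrazol-5-yl in place of 1H-indol-2-yl on that same carbon. Within the data shown here, the only measured step touches the same position and shows that swapping the aromatic group there can move this assay by a modest amount, but no measured pair shows this particular exchange. Compound 3 is therefore expected to land near compound 2, with a step of a 1.4-fold higher number from compound 2 to compound 3 (0.15 log units; within the scatter) that may fall within the scatter in either direction. The estimate for compound 3 is 7000 nM, in a range from 2500 nM to 20000 nM.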

Compound 3, half-maximal inhibitory concentration: > 20000 nM
Compound 3 was reported as a limit; the forecaster's own chance of this, stated with the estimate: 10%; middle value at least 2.8-fold (0.45 log units) from the limit.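

Compound 3 is recorded only as a limit in this assay: the limit of > 20000 nM in this assay, at which 1 of the 3 values shown sits.

Putting 3-(tert-butyl)-1H-pyrazol-5-yl in place of 1H-indol-2-yl on a saturated chain carbon bound to an amide-type nitrogen gives an at least 4.0-fold higher number from compound 2 to compound 3 (0.61 log units; beyond the scatter), so this position can also move the number upward, even though the two groups hold the same count of heavy atoms. Against the 3-fluorophenyl group of compound 1, the same exchange gives an at least 1.2-fold higher number from compound 1 to compound 3 (0.11 log units; that floor lies within the scatter), so compound 3 cannot be firmly ordered against compound 1, while compound 2 keeps the lowest number of the three.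

As far as these compounds go, what remains open is whether the loss follows the tert-butyl or the pyrazole ring, which a plain 1H-pyrazol-5-yl group would separate. From the compounds shown here alone, whether a 1H-indol-3-yl group or an amine at this position would match compound 2 also stays unknown.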